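Methyl for Chloro on the Aryl Ring of Compound 2

This account rests on a few compounds, and the source may have more. Where it says the series, first, only, none or still open, it means among the compounds named here.

Compound 1, `Cc1ccc(-c2cc(Cl)cc(C(=O)Nc3nn[nH]n3)n2)cc1`: 86%
Compound 2, `COc1cc(C(=O)Nc2nn[nH]n2)nc(-c2ccc(Cl)cc2)c1`: 0%

In a functional assay on the whole organism with Rattus norvegicus as the target, at a dose of 1 mg/kg by the oral route (a higher number here means a stronger effect of the compound at the dose given, a lower number a weaker effect), compound 1 gives 86%, and compound 2 gives 0%; the gap between the two lies beyond the scatter. Among the measured compounds shown here, compound 2 thus stands at the bottom of the two numbers, with compound 1 as its only neighbour. Compound 3, `COc1cc(C(=O)Nc2nn[nH]n2)nc(-c2ccc(C)cc2)c1`, is not yet measured. It differs from compound 2 in one place: methyl in place of chloro on an aromatic carbon. Compound 3 therefore carries the 4-methylphenyl of compound 1 together with the remainder of compound 2. For the measured compounds named here, no step between measured compounds isolates this single exchange, as the two measured compounds differ in two places at once, so its effect is uncertain. A moderate rise is nevertheless expected, a number 30 percentage points higher from compound 2 to compound 3 (beyond the scatter), because compound 1 with the same 4-methylphenyl gives 86%. Compound 3 is estimated at 30%, within 0% to 70%.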

Compound 3, a percentage reported as inhibition, in the whole organism at one dose (the size of the read-out at that dose, not a potency): 42%
Beside the measured number, compound 3's estimate is 12 percentage points below it; the range from low to high includes it.
By their numbers in this assay, from the lowest: compound 2; then compound 3; then compound 1.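

With the exchange of 4-chlorophenyl for 4-methylphenyl now isolated, this assay records a number 42 percentage points higher from compound 2 to compound 3 (beyond the scatter), so this place on the aryl ring alone separates no effect at the dose given from a clear one. With the 4-methylphenyl held constant, replacing the chloro on the core with methoxy gives a number 44 percentage points lower from compound 1 to compound 3 (beyond the scatter), which shows that chloro gives the higher number there. Each of the two places in which compound 1 and compound 2 differ therefore carries a large step of its own. Nothing available explains either step.

As far as these compounds go, whether an ethyl group or a trifluoromethyl group on the aryl ring would match or exceed the methyl remains open. So does how an amine or a fluoro group would compare with chloro and methoxy on the core.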